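The source may hold more compounds than are shown below. What is called first, only, known or untested is meant among the compounds shown, and "the series" means these compounds.

Compound 1 `Cc1ccc(Cn2cc(CO)c3ccccc32)cc1` gives 150 nM
Compound 2 `O=[N+]([O-])c1ccc(Cn2cc(CO)c3ccccc32)cc1` gives 150 nM
Compound 3 `COc1ccc(Cn2cc(CO)c3ccccc32)cc1` gives 63 nM

These three values come from a functional assay on T29Kt1 cells (Homo sapiens) for cytotoxicity, read by sulforhodamine B assay, with a stated time of 3 days; a higher number here means a weaker inhibitor, a lower number a stronger inhibitor. Compound 1 stands level with compound 2 at the top of this small set, while compound 3 has the lowest number. Compound 4 `Cc1ccc(Cn2cc(CO)c3cc(F)ccc32)cc1` keeps the methyl group of compound 1 and changes the shared core instead: fluoro in place of hydrogen on an aromatic carbon. Within the data shown here, the new fluoro sits on an aromatic carbon, para to a fused ring, and no measured compound carries this group or any other change at that place. The nearest evidence is therefore indirect. Replacing methyl by nitro gave no change at the digits printed from compound 1 to compound 2 (within the scatter), and replacing methyl by methoxy gave a 2.4-fold lower number from compound 1 to compound 3 (0.38 log units; beyond the scatter). Neither exchange of a single group went beyond a modest size, so only a small step is expected here, with no firm direction and probably none beyond the scatter. The expected change is a 1.3-fold lower number from compound 1 to compound 4 (0.10 log units; within the scatter). For compound 4 the estimated value is 120 nM, with an expected range from 50 nM to 300 nM.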

Compound 4, half-maximal inhibitory concentration: 30 nM
Beside the measured number, compound 4's estimate is 4.0-fold (0.60 log units) above it; the measured number lies below the stated range.
By their numbers in this assay, from the lowest: compound 4; then compound 3; then compounds 1 and 2 (each within the scatter of the next).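

In this assay, the step of a 5.0-fold lower number from compound 1 to compound 4 (0.70 log units; beyond the scatter) shows that the shared core itself can shift the number, and that a single fluoro on this aromatic carbon, para to a fused ring, is enough to do so. The earlier steps shown here had varied only the group that methyl occupies in compound 1, so they could say nothing about this place on the core. No measurement available here accounts for the step.

The compounds shown leave open whether a chloro, a methoxy or an amine at the same carbon would act as the fluoro does, or whether the fluoro is particular in this respect. They also leave open whether the fluoro would bring a similar step when combined with the methoxy of compound 3 or the nitro of compound 2.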